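Aryl replacement of the alkynol on the shared core

This account rests on a few compounds, and the source may have more. Where it says the series, first, only, none or still open, it means among the compounds named here.

Compound 1 `CC(C)(O)C#Cc1cc(C(O)(C(F)(F)F)C(F)(F)F)cnc1N1CCN(S(=O)(=O)c2ccc(N)nc2)CC1` stands in an ADME assay (liver) for metabolic stability, with Liver microsome (Homo sapiens) as the target, using microsomes and NADPH, with a stated time of 30 min, tested at 1 uM (on this read-out lower numbers stand for slow clearance and higher numbers for fast clearance), only as a limit: in this assay compound 1 gives < 14 mL.min-1.g-1, which is a limit of the assay rather than a number. Compound 2 `Nc1ccc(S(=O)(=O)N2CCN(c3ncc(C(O)(C(F)(F)F)C(F)(F)F)cc3-c3ccoc3)CC2)cn1` likewise gives < 14 mL.min-1.g-1, again a limit. Going by the values given here, the one measured step, a step that the two limits leave unreadable from compound 1 to compound 2, therefore cannot be read, since (the limit of < 14 mL.min-1.g-1 in this assay, at which 2 of the 2 values shown sit). Compound 3 `Nc1ccc(S(=O)(=O)N2CCN(c3ncc(C(O)(C(F)(F)F)C(F)(F)F)cc3-c3cccc(F)c3)CC2)cn1` is not yet measured; it differs from compound 1 by 3-fluorophenyl in place of 3-hydroxy-3-methylbut-1-yn-1-yl on an aromatic carbon. Among the compounds with values here, in compound 2 a ring also replaced the same chain on the shared core, and compound 2 sat at the limit, so the measured record offers no step of readable size to bear on the change. The expectation for compound 3 is a value at or near the limit, with a step that the limit leaves unreadable from compound 1 to compound 3 expected to be no step beyond the scatter. Compound 3 is estimated at 12 mL.min-1.g-1, within 5 mL.min-1.g-1 to 35 mL.min-1.g-1.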

Compound 3, intrinsic clearance in microsomes: 25 mL.min-1.g-1
Compound 3: middle estimate off by 2.1-fold (0.32 log units), on the low side; measured number inside the range.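

In this assay, going by these compounds alone, compound 3 gives 25 mL.min-1.g-1, the first value at this position on the shared core that is a number and not a limit. Putting 3-fluorophenyl in place of 3-hydroxy-3-methylbut-1-yn-1-yl gives an at least 1.7-fold higher number from compound 1 to compound 3 (0.25 log units; that floor lies within the scatter), and putting it in place of furan-3-yl gives an at least 1.7-fold higher number from compound 2 to compound 3 (0.25 log units; that floor lies within the scatter). An aromatic ring on this carbon therefore need not leave the read-out at the limit, though neither step is shown to exceed the scatter.

The full size of both steps cannot be read, because compound 1 and compound 2 are known only as limits: the limit of < 14 mL.min-1.g-1 in this assay, at which 2 of the 3 values shown sit. Still open, from the compounds shown here alone, is how an unsubstituted phenyl, or a phenyl carrying an amine or a carboxylic acid in place of the fluorine, would read at this position.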